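The source may report more compounds than this note shows. Statements on the series, on what has been measured and on what is new or still open speak of the compounds shown alone.

Compound 1 `Cc1cc(S(N)(=O)=O)ccc1NC(=O)COc1ccc(Cl)cc1Oc1ccc2ccccc2c1` and compound 2 `Cc1cc(S(N)(=O)=O)ccc1NC(=O)COc1ccc(F)cc1Oc1ccc2cc(C#N)ccc2c1` share a core and were both tested in an ADME assay on C8166 cells (Homo sapiens) for cytotoxicity, read by MTT assay; on this read-out lower numbers stand for higher toxicity in this test and higher numbers for lower toxicity in this test. In this assay compound 1 gives 119000 nM. For compound 2 the result is only a limit of the assay, > 395000 nM, and not a number. Compound 2 thus stands at the limit of > 395000 nM in this assay, at which 1 of the 2 values shown sits, rather than at a measured point. Compound 3 `Cc1cc(S(N)(=O)=O)ccc1NC(=O)COc1ccc(Cl)cc1Oc1ccc2cc(C#N)ccc2c1` is the unmeasured partner of compound 2, differing from it by chloro in place of fluoro on an aromatic carbon. Going by the values given here, no measured pair shows this exchange on this core, and the two values at hand come from compounds that differ in more than one place, so they give no reading of it. The step of an at least 1.3-fold lower number from compound 2 to compound 3 (0.11 log units; that floor lies within the scatter) is expected to remain within the scatter, in no clear direction. The estimate for compound 3 in this assay is 300000 nM, with a range from 100000 nM to 600000 nM.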

Compound 3, half-maximal cytotoxic concentration: > 383000 nM
Compound 3: no number, only a limit; the forecaster's own chance of this, stated with the estimate: 50%; middle value at least 1.2-fold (0.10 log units) away from the limit.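

In this assay, going by these compounds alone, cyano in place of hydrogen on an aromatic carbon gives an at least 3.2-fold higher number from compound 1 to compound 3 (0.50 log units; beyond the scatter), the first change in a single place on the shared core that can be read. Compound 3 gives > 383000 nM, which is a limit of the assay and not a number, so this step has a floor but no measured size. Compound 2 also stands at a limit, and the step for chloro in place of fluoro on an aromatic carbon cannot be read.

Still open, on these data alone, is how far the true value of compound 3 lies from that floor, and whether chloro and fluoro differ at all on this core. Also open, as far as these compounds go, is what an amine or a carboxylic acid in place of the cyano would give in this assay.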